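Removing a silicon-bearing group from a cytotoxic cyclopentenone

The source may hold more compounds than are shown below. What is called first, only, known or untested is meant among the compounds shown, and "the series" means these compounds.

Measured compounds:
Compound 1 `COc1ccc(C2=C(c3cc(OC)c(OC)c(OC)c3)C(=O)C(O[SiH2]C(C)(C)C)C2)cc1OC(C)C`: 7.1 ug/mL
Compound 2 `COc1ccc(C2=C(c3cc(OC)c(OC)c(OC)c3)C(=O)C(O[SiH2]C(C)(C)C)C2)cc1`: 16 ug/mL

In an ADME assay on HEp-2 cells (Homo sapiens) for cytotoxicity, read by MTT assay, with a stated time of 72 h (on this read-out lower numbers stand for stronger inhibition and higher numbers for weaker inhibition), compound 1 gives 7.1 ug/mL and stands as the lowest of the two numbers; its nearest neighbour is compound 2, which gives 16 ug/mL. Going by the values given here, the only measured step, a 2.3-fold higher number from compound 1 to compound 2 (0.35 log units; beyond the scatter), comes from exchanging one group on an aromatic carbon.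

Compound 3 `COc1ccc(C2=C(c3cc(OC)c(OC)c(OC)c3)C(=O)C(O)C2)cc1OC(C)C` differs from compound 1 elsewhere: a hydrogen atom in place of a group of 5 heavy atoms (4 carbon, 1 silicon; no ring), on an oxygen on a saturated carbon. Among the compounds with values here, no measured pair changes an oxygen on a saturated carbon, so the step from compound 1 to compound 2 does not bear on this change, and no direction can be argued from the data. The expectation for this assay is therefore a step of no clear direction, possibly within the scatter, with a wide margin either way. Compound 3 is estimated at 8 ug/mL (range 3 ug/mL to 22 ug/mL), which means an expected step of a 1.1-fold higher number from compound 1 to compound 3 (0.05 log units; within the scatter).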

Compound 3, half-maximal inhibitory concentration: > 100 ug/mL
Compound 3 was reported as a limit; the forecaster's own chance of this, stated with the estimate: 5%; middle value at least 12-fold (1.09 log units) from the limit.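

At the oxygen on a saturated carbon, the silicon-bearing group counts for much more than the earlier aromatic exchange did: in this assay, putting a hydrogen atom in its place gives an at least 14-fold higher number from compound 1 to compound 3 (1.14 log units; beyond the scatter), whereas the aromatic exchange gave only a 2.3-fold higher number from compound 1 to compound 2 (0.35 log units; beyond the scatter). The value of compound 3, > 100 ug/mL, is a limit of the assay and not a number. Among the compounds shown, then, the cytotoxicity of compound 1 depends strongly on what sits on this oxygen, which the first pair could not reveal.

Whether silicon itself matters stays open, since the compounds shown do not tell how a carbon-only group, such as a methyl or a tert-butyl, would behave on this oxygen. Nor do they tell whether the same change would have a similar effect in compound 2.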